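Moving the pyridyl ring to the other arm of the core

The source may report more compounds than this note shows. Statements on the series, on what has been measured and on what is new or still open speak of the compounds shown alone.

Measured so far:
compound 1, `O=C(O)C[C@H](O)C[C@H](O)CCn1c(C(F)(F)F)nc(-c2ccc(F)cc2)c1-c1ccc(F)cc1`: 38 nM
compound 2, `O=C(O)C[C@H](O)C[C@H](O)CCn1c(C(F)(F)F)nc(-c2cccnc2)c1-c1ccc(F)cc1`: 66 nM

Both were tested in an assay on microsomes from liver for inhibition of 3-hydroxy-3-methylglutaryl-coenzyme A reductase (Rattus norvegicus); on this read-out lower numbers stand for stronger inhibition and higher numbers for weaker inhibition. Within the data shown here, compound 1 gives the smaller of the two numbers, yet the only measured step, a 1.7-fold higher number from compound 1 to compound 2 (0.24 log units; within the scatter), stays within the scatter. Compound 3, `O=C(O)C[C@H](O)C[C@H](O)CCn1c(C(F)(F)F)nc(-c2ccc(F)cc2)c1-c1cccnc1`, carries the same swap at the second aryl-bearing carbon of the core: pyridin-3-yl in place of 4-fluorophenyl on an aromatic carbon. Among the measured compounds shown here, only that one step bears on it, and it was small. Compound 3 is therefore expected to land close to compound 1, with a 1.4-fold higher number from compound 1 to compound 3 (0.16 log units; within the scatter) as the estimated step, probably not beyond the scatter. The estimate for compound 3 is 55 nM, ranging from 25 nM to 120 nM.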

Compound 3, half-maximal inhibitory concentration: > 1000 nM
Compound 3 was reported as a limit (the forecaster's own chance of this, stated with the estimate: 2%); middle value at least 18-fold (1.25 log units) away from the limit.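

The same swap behaves differently at the two carbons of the shared core: a 1.7-fold higher number from compound 1 to compound 2 (0.24 log units; within the scatter) at one, but an at least 26-fold higher number from compound 1 to compound 3 (1.42 log units; beyond the scatter) at the carbon next to the ring atom that bears a 6-carboxy-3,5-dihydroxyhexyl group. In this assay, this carbon therefore tolerates pyridin-3-yl far less well than the other does. Compound 3 gives > 1000 nM, which is a limit of the assay and not a number.

The swap removes a fluorine and adds a ring nitrogen together, and these compounds cannot separate the two changes. A plain phenyl group at this carbon would show which one matters.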